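The source may report more compounds than this note shows. Statements on the series, on what has been measured and on what is new or still open speak of the compounds shown alone.

Of the compounds shown here, three have been measured in an assay on isolated protein for binding affinity to Leucine-rich repeat serine/threonine-protein kinase 2 (Homo sapiens), read by TR-FRET and LanthaScreen, with a stated time of 2 h; on this read-out higher numbers stand for weaker inhibition and lower numbers for stronger inhibition. Compound 1 `C[C@@H]1CCCN1c1[nH]c2ncnc(N)c2c1C#N` gives 4 nM, compound 2 `C[C@@H]1CCCN1c1c(C(N)=O)c2c(N)ncnc2n1C` gives 77 nM, and compound 3 `Cc1n[nH]cc1Nc1nc(N)c2c(C#N)c(N3CCC[C@H]3C)n(C)c2n1` gives 1 nM. Compound 3 has the lowest number of the three, and the gaps to compound 1 and to compound 2 both lie beyond the usual scatter, so compound 3 is the strongest binder measured so far.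

The next compound, compound 4 `C[C@@H]1CCCN1c1c(C#N)c2c(N)ncnc2n1C`, differs from compound 3 in one place: hydrogen in place of (3-methyl-1H-pyrazol-4-yl)amino on an aromatic carbon. A sizeable group is thus replaced by a single hydrogen atom, leaving a smaller molecule that otherwise keeps the core of compound 3.

Within the data shown here, with no directly comparable pair among the measured compounds, the size of this step can only be guessed. Taking away a group of this size is expected to weaken binding, so the number in this assay should rise, and the step from compound 3 to compound 4 is estimated at a 12-fold higher number from compound 3 to compound 4 (1.08 log units; beyond the scatter). Compound 4 is therefore expected to give about 12 nM, with a plausible range from 3 nM to 45 nM.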

Compound 4, inhibition constant: 0.4 nM
Compound 4: middle estimate off by 30-fold (1.48 log units), on the high side, and the stated range ends above it.
By their numbers in this assay, from the lowest: compound 4; then compound 3; then compound 1; then compound 2.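

In this assay, the (3-methyl-1H-pyrazol-4-yl)amino group on this aromatic carbon proves dispensable for binding: replacing it with hydrogen, which removes a whole aromatic ring, gives a 2.5-fold lower number from compound 3 to compound 4 (0.40 log units; beyond the scatter) and so tightens binding rather than weakening it. Among these compounds, compound 4 also links the earlier compounds through single changes elsewhere on the shared core, with nitrile in place of carbamoyl giving a 190-fold lower number from compound 2 to compound 4 (2.28 log units; beyond the scatter), a large step, and methyl in place of hydrogen on an aromatic nitrogen giving a 10-fold lower number from compound 1 to compound 4 (1.00 log units; beyond the scatter), a modest one. Nothing measured here explains why any of these changes strengthens binding.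

Going by these compounds, whether a small group such as methoxy or fluorine on the same carbon would match hydrogen remains open. On these data alone, it is also open whether the gain from the nitrile would persist with the (3-methyl-1H-pyrazol-4-yl)amino group in place.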